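From Compound 3 to Compound 4: One Aryl Swap

The source may report more compounds than this note shows. Statements on the series, on what has been measured and on what is new or still open speak of the compounds shown alone.

In a physicochemical assay for solubility (on this read-out lower numbers stand for lower solubility and higher numbers for higher solubility), compound 3 `CCCS(=O)(=O)N1CCC(CNC(=O)c2c(F)ccc(Cl)c2F)(C(=O)N2CCOCC2)CC1` gives 10000 ug/mL and stands level with compound 1 `CCCS(=O)(=O)N1CCC(CNC(=O)C2CC2)(C(=O)N2CCOCC2)CC1` at 10000 ug/mL and compound 2 `CCCS(=O)(=O)N1CCC(CNC(=O)c2ccc(F)cc2C(F)(F)F)(C(=O)N2CCOCC2)CC1` at 10000 ug/mL on the digits shown. The unmeasured compound 4 `CCCS(=O)(=O)N1CCC(CNC(=O)c2ccccc2Cl)(C(=O)N2CCOCC2)CC1` differs from compound 3 by one exchange on a carbonyl carbon: 2-chlorophenyl in place of 3-chloro-2,6-difluorophenyl on a carbonyl carbon is the counted change, with 2-chlorophenyl in place of 3-chloro-2,6-difluorophenyl. Within the data shown here, three measured steps touch that same place: no change at the digits printed from compound 1 to compound 2 (within the scatter) and no change at the digits printed from compound 1 to compound 3 (within the scatter) and also no change at the digits printed from compound 2 to compound 3 (within the scatter) all stay within the scatter. Among the measured compounds shown here, no measured compound carries 2-chlorophenyl, so the expectation is an extrapolation. The expected result is no change at the digits printed from compound 3 to compound 4 (within the scatter) with no shift beyond the scatter in either direction. Compound 4 is estimated at 10000 ug/mL within an expected range from 5000 ug/mL to 10000 ug/mL overall.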

Compound 4, solubility: 10000 ug/mL
Beside the measured number, compound 4's estimate shows no gap at the digits printed; measured number inside the range.
By their numbers in this assay, from the lowest: compounds 1, 2, 3 and 4 (each within the scatter of the next).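

In this assay the place on the carbonyl carbon, whose other neighbour is an amide-type nitrogen, now holds 2-chlorophenyl, the only aryl group shown there without fluorine, and no difference appears against any earlier group (no change at the digits printed from compound 3 to compound 4 (within the scatter); no change at the digits printed from compound 2 to compound 4 (within the scatter); no change at the digits printed from compound 1 to compound 4 (within the scatter)). Aryl groups with and without fluorine therefore read alike at this position across these four compounds. No available evidence accounts for this.

Going by these compounds, whether a group holding an amine or a carboxylic acid at this place would separate from these four compounds stays open, as does the effect of any change elsewhere on the shared core.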